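Shortening the Side Chain on a Shared Core

The source may report more compounds than this note shows. Statements on the series, on what has been measured and on what is new or still open speak of the compounds shown alone.

Measured so far:
compound 1, `COc1ccc2c(c1)[n+]([O-])nc(NCOC(C)c1ccccc1)[n+]2[O-]`: 220 nM
compound 2, `CCCCCOCNc1n[n+]([O-])c2ccccc2[n+]1[O-]`: 2900 nM
compound 3, `[O-][n+]1nc(NCOCc2ccc(C(F)(F)F)cc2)[n+]([O-])c2ccccc21`: 4270 nM

All three compounds share the same core and were tested in a functional assay on A549 cells (Homo sapiens) for cytotoxicity, read by MTT assay, with a stated time of 72 h; on this read-out higher numbers stand for weaker inhibition and lower numbers for stronger inhibition. Compound 1 gives 220 nM and stands apart from the other two. Compound 2 gives 2900 nM, the second highest of the three numbers; compound 3 gives 4270 nM, and the gap between compound 2 and compound 3 lies within the scatter, so no order between them can be read. The gap between compound 2 and compound 1 lies beyond the scatter.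

Compound 4, `CCOCNc1n[n+]([O-])c2ccccc2[n+]1[O-]`, has not yet been measured. It differs from compound 2 in one place: hydrogen in place of propyl on a saturated chain carbon, two bonds along the chain from an oxygen on a saturated carbon. Put another way, pentyloxy becomes ethoxy. Among the measured compounds shown here, no step between measured compounds touches this chain, so there is nothing directly to compare. With so little to build on, the expected step from compound 2 to compound 4 in this assay is small, a 1.4-fold higher number from compound 2 to compound 4 (0.14 log units; within the scatter), likely within the scatter, with a slight lean toward a higher number. Compound 4 is therefore estimated at 4000 nM, with a range from 1500 nM to 12000 nM.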

Compound 4, half-maximal inhibitory concentration: 4090 nM
Estimate against measurement, compound 4: 1.0-fold (0.01 log units) below, within the range that was stated.
By their numbers in this assay, from the lowest: compound 1; then compounds 2, 4 and 3 (each within the scatter of the next).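

In this assay, among the compounds shown here, the change from pentyloxy to ethoxy gives a 1.4-fold higher number from compound 2 to compound 4 (0.15 log units; within the scatter) and so provides the only direct comparison on this chain. At this place, two bonds along the chain from an oxygen on a saturated carbon, losing the propyl piece leaves no difference that can be told from ordinary assay scatter. The chain can therefore be either pentyloxy or ethoxy without a readable shift in this cell read-out, and nothing measured here offers an explanation for that.

Going by these compounds, whether a much longer chain, or a chain ending in an amine or a carboxylic acid, would shift the number remains open. So does whether the same shortening would read the same way on the core of compound 1.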